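Swapping the Aryl Group on a Triazole in Weak Antiproliferatives

The compounds below may be only part of what the source reports. "The series", "measured", "known", "first", "only" and "open" are said of these compounds alone.

Three compounds share one core and were tested in a functional assay on HCT-116 cells (Homo sapiens) for antiproliferative activity, read by MTT assay, with a stated time of 48 h; a higher number here means a weaker inhibitor, a lower number a stronger inhibitor. Compound 1 `C#CCOc1ccc(/C=C/C(C)=O)cc1OC` gives 49700 nM. Compound 3 `COc1cc(/C=C/C(C)=O)ccc1OCc1cn(-c2ccccc2)nn1` gives 67300 nM. Compound 2 `COc1cc(/C=C/C(C)=O)ccc1OCc1cn(-c2ccccc2CO)nn1` differs from compound 3 only by a hydroxymethyl on an aromatic carbon. For compound 2 this assay reports no number but only a limit, > 100000 nM. That places compound 2 at the limit of > 100000 nM in this assay, at which 1 of the 3 values shown sits, so its real value is not pinned down.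

Compound 4 `COc1cc(/C=C/C(C)=O)ccc1OCc1cn(-c2cc(F)cc(Br)c2)nn1` has not yet been measured. It differs from compound 2 by 3-bromo-5-fluorophenyl in place of 2-(hydroxymethyl)phenyl on an aromatic nitrogen. For the measured compounds named here, the only measured step that touches this part of the molecule is the one where an at least 1.4-fold lower number from compound 2 to compound 3 (0.17 log units; that floor lies within the scatter): taking the hydroxymethyl away did not push the number up, and may have lowered it, though the floor of that step is within the scatter. Nothing measured speaks to what a bromine and a fluorine on that ring do, so the expectation leans on compound 3 as the nearest anchor.

Compound 4 is therefore expected to sit near compound 3, with an estimate of 55000 nM and a range from 20000 nM to 150000 nM. The step of an at least 1.8-fold lower number from compound 2 to compound 4 (0.25 log units; that floor lies within the scatter) is thus expected to be downward, but with a real chance that this assay again reports only a limit.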

Compound 4, half-maximal inhibitory concentration: 45400 nM
Estimate against measurement, compound 4: 1.2-fold (0.08 log units) above; the measured number falls inside the stated range.
By their numbers in this assay, from the lowest: compounds 4, 1 and 3 (each within the scatter of the next). At a limit, above all of these: compound 2.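

Replacing the 2-(hydroxymethyl)phenyl on this aromatic nitrogen with 3-bromo-5-fluorophenyl gives a step at this position that clears the scatter in this assay: an at least 2.2-fold lower number from compound 2 to compound 4 (0.34 log units; beyond the scatter). Compound 2 has only a limit and not a number, so this step gives a floor and its full size stays unknown: the limit of > 100000 nM in this assay, at which 1 of the 4 values shown sits.

The step against the plain phenyl, a 1.5-fold lower number from compound 3 to compound 4 (0.17 log units; within the scatter), does not separate the two compounds, so bromine and fluorine together are tolerated on this ring but are not shown to improve on it.

The two atoms enter together, so the compounds shown leave open what bromine alone or fluorine alone would do on this ring, and whether their places on it matter. They also leave open whether an amine or a carboxylic acid on this phenyl ring, or a longer chain in place of the ring, would move the number in this assay beyond the scatter in either direction.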